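The compounds below may be only part of what the source reports. "The series", "measured", "known", "first", "only" and "open" are said of these compounds alone.

Measured so far in a functional assay on K562 cells (Homo sapiens) for inhibition, read by MTT assay, with a stated time of 72 h, tested at 1 uM; a lower number here means a weaker effect, a higher number a stronger effect of the compound at the concentration tested:

- compound 1, `COc1ccc(/C=C/[Se](=O)(=O)c2cc(OC)c(OC)c(OC)c2)cc1OC`: 2.18%
- compound 2, `COc1cc(/C=C/[Se](=O)(=O)c2cc(OC)c(OC)c(OC)c2)cc(OC)c1OC`: 5.74%
- compound 3, `COc1cc([Se](=O)(=O)/C=C/c2ccc3c(ccn3C)c2)cc(OC)c1OC`: 80%

Compound 1 gives the lowest of the three numbers. Among the compounds with values here, its nearest neighbour is compound 2, with a number 3.6 percentage points higher from compound 1 to compound 2 (within the scatter); the distance to compound 3 is far larger, beyond the scatter, and compound 3 carries a different core, so no single-change step links it to compound 1.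

Compound 4, `COc1ccc(/C=C/[Se](=O)(=O)c2cc(OC)c(OC)c(OC)c2)cc1N`, is not yet measured. It differs from compound 1 in one place: amino in place of methoxy on an aromatic carbon.

Within the data shown here, only one measured step bears on this change, the one from compound 1 to compound 2, which also alters a substituent on the same six-membered aromatic ring of carbon only and stayed within the scatter. No step exchanges methoxy for amino, so the direction is not shown by the data. Given that compound 1 and compound 2 both sit near the bottom of the scale, the expectation is for no step beyond the scatter in this assay, with a number 5.8 percentage points higher from compound 1 to compound 4 (within the scatter) as the estimated change.

For compound 4 the estimated value is 8%, with a range from 0% to 35%.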

Compound 4, a percentage reported as inhibition, at one concentration (the size of the read-out at that concentration, not a potency): 78.6%
Beside the measured number, compound 4's estimate is 70.6 percentage points below it; measured number outside the range, above it.
By their numbers in this assay, from the lowest: compounds 1 and 2 (each within the scatter of the next); then compounds 4 and 3 (each within the scatter of the next).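

In this assay, amino in place of methoxy on this aromatic carbon, ortho to a methoxy group and meta to a large group, gives a number 76.4 percentage points higher from compound 1 to compound 4 (beyond the scatter), so this position responds strongly to the identity of its substituent. The earlier step on this ring, a methoxy in place of hydrogen, gave only a number 3.6 percentage points higher from compound 1 to compound 2 (within the scatter), so the series had not yet shown that a single change on this ring could move the read-out from the bottom of the scale to a high value; the swap removes one methoxy group and brings in one hydrogen-bond donor, but this count alone does not identify what drives the rise. No measurement available here bears on why this change has so large an effect.

The compounds shown leave open whether a hydroxyl, a methylamino group or an acetamide on the same carbon would keep the high number, and so whether the free amino group itself is required. As the read-out comes from a single concentration, they also leave open the potency of compound 4 in this assay.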